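The source may report more compounds than this note shows. Statements on the series, on what has been measured and on what is new or still open speak of the compounds shown alone.

Compound 2 `CC(=O)Nc1ccc(S(=O)(=O)N2C/C(=C\c3cccnc3)C(=O)/C(=C/c3ccccc3F)C2)cc1` gives 10900 nM in a functional assay on SMMC-7721 cells (Homo sapiens) for cytotoxicity, read by MTT assay, with a stated time of 24 h; on this read-out higher numbers stand for weaker inhibition and lower numbers for stronger inhibition. Its number is the lowest of the three measured here, though not by a margin that means anything: compound 1 `O=C1/C(=C/c2cccnc2)CN(S(=O)(=O)c2ccc(Cl)cc2)C/C1=C\c1ccccc1F` gives 16100 nM and compound 3 `CC(=O)Nc1ccc(S(=O)(=O)N2C/C(=C\c3ccncc3)C(=O)/C(=C/c3ccccc3F)C2)cc1` gives 13400 nM, and both gaps sit within the scatter. The two measured steps, a 1.5-fold lower number from compound 1 to compound 2 (0.17 log units; within the scatter) and a 1.2-fold higher number from compound 2 to compound 3 (0.09 log units; within the scatter), each alter a different part of the molecule, and neither moves the number beyond the scatter.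

Compound 4 `CC(=O)Nc1ccc(S(=O)(=O)N2C/C(=C\c3cccnc3)C(=O)/C(=C/c3ccccc3C(F)(F)F)C2)cc1` is compound 2 with one change: trifluoromethyl in place of fluoro on an aromatic carbon. Going by the values given here, no measured step touches this group or this part of the shared core, so the data give no direct guide for it. With both measured changes elsewhere on the shared core having produced nothing beyond the scatter, the step from compound 2 to compound 4 is expected to be small as well, a 1.0-fold higher number from compound 2 to compound 4 (0.00 log units; within the scatter), with no direction preferred. Compound 4 is therefore estimated at 11000 nM in this assay, with a range from 4000 nM to 30000 nM that is kept wide for lack of any closer precedent.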

Compound 4, half-maximal inhibitory concentration: 9830 nM
For compound 4 the middle estimate is 1.1-fold (0.05 log units) above the measured one; measured number inside the range.
By their numbers in this assay, from the lowest: compounds 4, 2, 3 and 1 (each within the scatter of the next).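

Placing trifluoromethyl on this aromatic carbon, ortho to a large group, gives the first measured change at this part of the molecule, and in this assay it yields a 1.1-fold lower number from compound 2 to compound 4 (0.04 log units; within the scatter). The step from 2-fluorophenyl to 2-(trifluoromethyl)phenyl brings in more heavy atoms, yet the number stays within the scatter, so these two groups cannot be told apart in this assay. Nothing available bears on what lies behind this result.

From the compounds shown here alone, how an amine or a carboxylic acid on this same aromatic carbon would read remains open, and so does the reading with plain hydrogen there. Going by these compounds, with the four compounds each within the scatter of the next, it also remains open whether any change at this position can move the number beyond the scatter.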